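Piperidine replaces benzylamine in a series stuck at the limit

The source may hold more compounds than are shown below. What is called first, only, known or untested is meant among the compounds shown, and "the series" means these compounds.

Three amides sharing one core were tested in an in vitro assay on HEK-tsA201 cells for antagonist activity at Neuronal acetylcholine receptor; alpha4/beta2 (Homo sapiens), read by fluorescence and calcium flux; a higher number here means a weaker inhibitor, a lower number a stronger inhibitor. Compound 1 `CCCOc1ccc(C(=O)Nc2cccc(Cl)n2)cc1` carries a chloro group on an aromatic carbon. In this assay compound 1 gives > 100000 nM, which is a limit of the assay and not a number. Compound 2 `CCCOc1ccc(C(=O)Nc2cccc(Nc3ccccc3)n2)cc1` has an anilino group in that position. Compound 2 gives > 100000 nM, again a limit. Compound 3 `CCCOc1ccc(C(=O)Nc2cccc(NCc3ccccc3)n2)cc1` has a benzylamino group there. Compound 3 gives > 100000 nM, also a limit. The step that the two limits leave unreadable from compound 1 to compound 2, the step that the two limits leave unreadable from compound 1 to compound 3 and the step that the two limits leave unreadable from compound 2 to compound 3 cannot be sized because of the limit of > 100000 nM in this assay, at which 3 of the 3 values shown sit. Compound 3 therefore stands where every other measured compound stands, at the limit, with no number to set it apart.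

Compound 4 `CCCOc1ccc(C(=O)Nc2cccc(N3CCCCC3)n2)cc1` has not yet been measured. It differs from compound 3 by piperidin-1-yl in place of benzylamino on an aromatic carbon. The three measured steps bear on this change only in that each of them is unreadable; none shows a direction or a size. The step of a number no higher from compound 3 to compound 4 (the limit leaves the size open) is thus expected to be one that cannot be read either. For compound 4 the estimate in this assay is 100000 nM, within a range from 30000 nM to 300000 nM, and most likely the assay will again report only a limit.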

Compound 4, half-maximal inhibitory concentration: > 100000 nM
Compound 4 was reported as a limit; the forecaster's own chance of this, stated with the estimate: 85%; the middle value sits exactly at the limit.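

In this assay compound 4 gives > 100000 nM, a limit of the assay and not a number. No step from compound 1, compound 2 or compound 3 to compound 4 can be read: the limit of > 100000 nM in this assay, at which 4 of the 4 values shown sit.

The compounds shown leave open whether any of these four groups on the shared core gives a measurable inhibition in this assay, and how far the four compounds differ.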